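This account rests on a few compounds, and the source may have more. Where it says the series, first, only, none or still open, it means among the compounds named here.

Working notes on the cytotoxicity series.

Among the measured compounds shown here, compound 2 `COc1ccc(-c2nc3c(C(=O)Nc4cnc(Cl)cn4)cccc3[nH]2)cc1OC` gives the highest of the two numbers so far in an ADME assay on Vero cells (Chlorocebus sabaeus) for cytotoxicity (on this read-out lower numbers stand for higher toxicity in this test and higher numbers for lower toxicity in this test), at 78.3 uM. For the measured compounds named here, its nearest neighbour is compound 1 `CCC(CC)NC(=O)c1cccc2[nH]c(-c3ccc(OC)c(OC)c3)nc12`, which in this assay gives 2.23 uM; the only step between them, a 35-fold higher number from compound 1 to compound 2 (1.55 log units; beyond the scatter), arises from a 5-chloropyrazin-2-yl in place of pentan-3-yl on the amide-type nitrogen.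

Compound 3 `COc1ccc(-c2nc3c(C(=O)Nc4ncc[nH]4)cccc3[nH]2)cc1OC` is not yet measured. It differs from compound 2 by 1H-imidazol-2-yl in place of 5-chloropyrazin-2-yl on an amide-type nitrogen. Going by the values given here, the one measured step exchanges an open chain for an aromatic ring on that nitrogen, whereas this step exchanges one aromatic ring for another, so it bears on the question only loosely. Among the compounds with values here, with no closer precedent, the expectation for compound 3 is a step of a 1.3-fold lower number from compound 2 to compound 3 (0.12 log units; within the scatter), not beyond the scatter. Compound 3 is therefore estimated at 60 uM, with a range from 20 uM to 150 uM.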

Compound 3, half-maximal toxic concentration: "not active" (no number reported)
Compound 3: no number reported; no gap can be computed for the estimate.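

In this assay, among the compounds shown here, compound 3 is recorded only as "not active", with no number, and no step from compound 2 to compound 3 can be read. The compounds shown leave open how 1H-imidazol-2-yl compares numerically with 5-chloropyrazin-2-yl on the amide-type nitrogen. No evidence bears on this result.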